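This account rests on a few compounds, and the source may have more. Where it says the series, first, only, none or still open, it means among the compounds named here.

Three compounds share one core, and each was tested in an assay on HEK293 cells for inhibition of Steryl-sulfatase (Homo sapiens), tested at 0.1 uM; a higher number here means a stronger effect of the compound at the concentration tested, a lower number a weaker effect. Compound 1 `CN(C)CCN(CCN(C)C)c1cccc(C(=O)N2CCc3ccc(OS(N)(=O)=O)cc3C2)c1` gives 0%. Compound 2 `CCN(Cc1ccccn1)c1ccc(C(=O)N2CCc3ccc(OS(N)(=O)=O)cc3C2)cc1` gives 42.5%, the highest of the three numbers. Compound 3 `NS(=O)(=O)Oc1ccc2c(c1)CN(C(=O)c1cccc(N(Cc3ccccc3)Cc3ccco3)c1)CC2` gives 27.5%. Compound 2 stands above its nearest neighbour, compound 3, by a gap that is beyond the usual scatter, and above compound 1 by a still wider gap that is also beyond the scatter.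

Compound 4 `CCCN(Cc1ccccc1)c1ccc(C(=O)N2CCc3ccc(OS(N)(=O)=O)cc3C2)cc1` has not yet been measured. It differs from compound 2 in one place: benzyl(propyl)amino in place of ethyl((pyridin-2-yl)methyl)amino on an aromatic carbon. The change swaps the six-membered aromatic ring with one hetero atom for a six-membered aromatic ring of carbon only and lengthens the short chain on the same nitrogen.

Within the data shown here, no measured pair here isolates this exact change, so the expectation rests on the neighbours. Compound 3, which also carries a benzyl group on its nitrogen, gives 27.5%, a value below compound 2. A modest downward step is therefore expected in this assay, estimated as a number 9.5 percentage points lower from compound 2 to compound 4 (within the scatter). Compound 4 is expected to give about 33%, with a plausible range from 15% to 52%.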

Compound 4, a percentage reported as inhibition, at one concentration (the size of the read-out at that concentration, not a potency): 64.8%
The estimate for compound 4 lay 31.8 percentage points below the measured number, outside the stated range (above it).
By their numbers in this assay, from the lowest: compound 1; then compound 3; then compound 2; then compound 4.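

In this assay, replacing ethyl((pyridin-2-yl)methyl)amino with benzyl(propyl)amino on the aromatic carbon para to a large group gives a number 22.3 percentage points higher from compound 2 to compound 4 (beyond the scatter). This shows that the ring hetero atom of compound 2 is not required for the effect at this position, since a six-membered aromatic ring of carbon only, with one hydrogen-bond acceptor fewer in the group, comes with a higher number rather than a loss. The ring and the chain on the nitrogen change in the same step, however, and nothing measured here accounts for the rise.

As far as these compounds go, it remains open how much of the step belongs to the ring and how much to the chain, a question that benzyl(ethyl)amino at the same place, which changes the ring alone, could help to separate. Also open, from the compounds shown here alone, is how this position responds to a longer chain such as butyl on the same nitrogen, or to a fluorine atom or a methoxy group on the benzyl ring.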